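Fluoro for Chloro: Estimating Compound 3

A few compounds are considered here, and "the series" means these few. Any claim that something is new, unique, unknown or untested is made for them only; others in the source may bear on it.

Within the data shown here, compound 1 `CC1CCN(c2c(S(=O)(=O)c3ccc(Cl)cc3)cnc3c(F)cccc23)CC1` is one of two compounds measured in an assay on isolated protein for displacement of a labelled ligand from metabotropic glutamate receptor 5 (Homo sapiens), with a stated time of 60 min, tested at 1 uM (on this read-out lower numbers stand for less inhibition and higher numbers for more inhibition at the one concentration tested (going by the name of the read-out)), where compound 1 gives 85%. Compound 2 `Cc1ccc(S(=O)(=O)c2cnc3ccc(F)cc3c2N2CCC(C)CC2)cc1Cl` in this assay gives 91%; these two values fall within the usual scatter of each other, so nothing separates them. Compound 3 `CC1CCN(c2c(S(=O)(=O)c3ccc(F)cc3)cnc3c(F)cccc23)CC1` has not yet been measured. It differs from compound 1 by a single change: fluoro in place of chloro on an aromatic carbon. Among the measured compounds shown here, no measured pair shows this change, so the step of a number 5 percentage points lower from compound 1 to compound 3 (within the scatter) is expected to stay within the scatter, with no direction favoured. Compound 3 is thus expected to give about 80%, between 60% and 95%.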

Compound 3, a percentage reported as inhibition, at one concentration (the size of the read-out at that concentration, not a potency): 26%
Compound 3: middle estimate off by 54 percentage points, on the high side; the measured number lies below the stated range.
By their numbers in this assay, from the lowest: compound 3; then compounds 1 and 2 (each within the scatter of the next).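

In this assay, replacing 4-chlorophenyl with 4-fluorophenyl gives a number 59 percentage points lower from compound 1 to compound 3 (beyond the scatter). This shows that the exchange of one halogen for another at this place, para to a large group, is not a neutral change on the core of compound 1, and that the read-out there depends strongly on which halogen is present. Nothing available bears on why the two compounds differ. The compounds shown leave open how a bromo or a methoxy group at this place would read, and whether the same exchange would produce as large a step on the core of compound 2.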